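Inverting the stereocentre of a butylphenyl urea

This account rests on a few compounds, and the source may have more. Where it says the series, first, only, none or still open, it means among the compounds named here.

Compound 1 `Cc1ccc(NC(=O)N[C@@H](C)c2ccccc2)cc1`: 100%
Compound 2 `CCCCc1ccc(NC(=O)N[C@H](C)c2ccccc2)cc1`: 100%

In an ADME assay on the whole organism with Oryza sativa as the target, tested at 0.1 uM (on this read-out higher numbers stand for a weaker effect at the one concentration tested and lower numbers for a stronger effect), compound 1 gives 100% and compound 2 gives 100%; the two values lie within the scatter of each other, so compound 2 stands level with compound 1. Among the compounds with values here, compound 3 `CCCCc1ccc(NC(=O)N[C@@H](C)c2ccccc2)cc1` has not yet been measured in this assay. the two compounds have the same atoms and bonds and differ only in configuration as drawn: 1 of 1 stereo elements differ; a stereocentre at a saturated chain carbon is drawn R in compound 2 and S in compound 3 The configuration drawn for compound 3 is the one that compound 1 already carries, and compound 1 gave 100%. The expected step is therefore none beyond the scatter, a number 2 percentage points lower from compound 2 to compound 3 (within the scatter). Compound 3 is estimated to give 98% in this assay, within 85% to 105%.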

Compound 3, a percentage reported as activity, at one concentration (the size of the read-out at that concentration, not a potency): 98%
For compound 3 middle estimate and measured number coincide at the digits printed, within the range that was stated.
By their numbers in this assay, from the lowest: compounds 3, 1 and 2 (each within the scatter of the next).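

In this assay, inverting the stereocentre at the saturated chain carbon gives a number 2 percentage points lower from compound 2 to compound 3 (within the scatter), so the read-out does not separate the two configurations at the one concentration tested, and nothing else can account for that comparison: the fact that compounds 2 and 3 differ only in the configuration as drawn With the configuration held the same, propyl in place of hydrogen on a saturated chain carbon bound to an aromatic carbon gives a number 2 percentage points lower from compound 1 to compound 3 (within the scatter), so the read-out does not separate the longer chain from the shorter one either. From the compounds shown here alone, what stays open is whether any change on the shared core can move this read-out, for instance a carboxylic acid or an amine at the end of that chain.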